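A few compounds are considered here, and "the series" means these few. Any claim that something is new, unique, unknown or untested is made for them only; others in the source may bear on it.

Measured so far:
compound 1, `COc1nc2nc(C(=O)c3ccccc3)cn2c(C)c1CC1CC1`: 10 mg/kg
compound 2, `CCCc1cc(OC)nc2nc(C(=O)c3ccccc3)cn12`: 1 mg/kg

In a functional assay on the whole organism with Rattus norvegicus as the target (on this read-out higher numbers stand for an effect only at larger amounts of compound and lower numbers for an effect already at smaller amounts), compound 1 gives 10 mg/kg, the highest of the two numbers on hand. Compound 2 gives 1 mg/kg in this assay, and the gap between the two values lies beyond the usual scatter. Going by the values given here, compound 2 differs from compound 1 in more than one place, so the two values show only that compound 1 needs the larger amount; no single step between them can be read off.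

Compound 3, `COc1nc2nc(C(=O)c3ccccc3)cn2c(C)c1OC`, remains to be measured in this assay. It differs from compound 1 in one place: methoxy in place of cyclopropylmethyl on an aromatic carbon The shared core, the methoxy already present and the methyl are kept. Nothing in the measured pair isolates what the cyclopropylmethyl contributes on its own, so the direction of this change rests on little. A modest step toward a lower number is expected, a 2.0-fold lower number from compound 1 to compound 3 (0.30 log units; within the scatter), most likely not clearly beyond the scatter. For compound 3 the estimate in this assay is 5 mg/kg, with a range from 1 mg/kg to 30 mg/kg.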

Compound 3, minimum effective dose: 5 mg/kg
For compound 3 middle estimate and measured number coincide at the digits printed; low and high end bracket the measured number.
By their numbers in this assay, from the lowest: compound 2; then compounds 3 and 1 (each within the scatter of the next).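

Going by these compounds alone, the step of a 2.0-fold lower number from compound 1 to compound 3 (0.30 log units; within the scatter) in this assay is the first reading of a single change at this position, the aromatic carbon ortho to a methoxy group and ortho to a methyl group. On this read-out, methoxy, with no ring and one hydrogen-bond acceptor, cannot be told apart from cyclopropylmethyl, with its three-membered carbon ring and no acceptor, so neither that ring nor the added acceptor shows up as a separable contribution in this pair. No measurement is at hand that explains why the two groups read alike.

Going by these compounds, with only these two groups compared at this position, it remains open whether an amine, a carboxylic acid, a hydroxyl or a longer chain such as n-butyl there would move the minimum effective dose beyond the scatter in either direction. Compound 2 differs from each of the other compounds in more than one place, so its standing cannot be assigned to any single group, and a one-place partner for it, such as a version of compound 2 carrying methoxy on this aromatic carbon, would be needed to settle that.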